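The source may report more compounds than this note shows. Statements on the series, on what has been measured and on what is new or still open speak of the compounds shown alone.

Measured in an ADME assay on microsomes from liver (Homo sapiens) for metabolic stability; a higher number here means faster removal of the compound, a lower number slower removal:
compound 1, `CN(C)C(=O)CN1CCC(c2cc3c(-c4ccc(=O)n(C)c4)ccnc3[nH]2)CC1`: < 3 uL/min
compound 2, `CC(C)n1cc(-c2ccnc3[nH]c(C4CCN(CC(=O)N5CCCCC5)CC4)cc23)ccc1=O`: > 300 uL/min

Compound 2 stands only at a limit of this assay, > 300 uL/min, with no number behind it. Compound 1 sits at the opposite limit of this assay, < 3 uL/min, likewise without a number. Going by the values given here, no computed step joins the two; what is known is that their values rest at the limit of < 3 uL/min in this assay, at which 1 of the 2 values shown sits, and (the limit of > 300 uL/min in this assay, at which 1 of the 2 values shown sits). Compound 3 `CNC(=O)CN1CCC(c2cc3c(-c4ccc(=O)n(C(C)C)c4)ccnc3[nH]2)CC1` carries methylamino in place of piperidin-1-yl on a carbonyl carbon. The change from compound 2 to compound 3 is expected to lower the reading in this assay well beyond the scatter, by a step of an at least 10-fold lower number from compound 2 to compound 3 (1.00 log units; beyond the scatter). Compound 3 is estimated at 30 uL/min in this assay, within 5 uL/min to 150 uL/min.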

Compound 3, intrinsic clearance in a liver preparation (reported as CLH), per the amount of preparation that the assay uses in the Homo sapiens assay: 8.6 uL/min
Estimate against measurement, compound 3: 3.5-fold (0.54 log units) above; measured number inside the range.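

At this carbonyl carbon, methylamino in place of piperidin-1-yl brings a large fall in the Homo sapiens assay: an at least 34-fold lower number from compound 2 to compound 3 (1.54 log units; beyond the scatter). Compound 2 stands at a limit of this assay, so the step has no upper bound. In a physicochemical assay for acid dissociation, compound 2 gives 7.8 and compound 3 gives 6.9, so this read-out differs as well.

The pair does not separate the loss of the ring from the gain of the amide hydrogen. A pyrrolidin-1-yl or ethylamino group on this carbonyl carbon would show how the reading follows ring size and chain length.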